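The compounds below may be only part of what the source reports. "The series", "measured", "known", "first", "only" and "open" are said of these compounds alone.

Compound 1, `CN1CCN(c2nc(Cl)nc3c2ncn3Cc2ccc(C(=O)Nc3ccccc3N)cc2)CC1`, gives 75%.
Compound 2, `Nc1ccccc1NC(=O)/C=C/c1ccc(Cn2cnc3c(NC4CCCCC4)nc(Cl)nc32)cc1`, gives 42.7%.
Compound 3, `CCCCn1cnc2c(Nc3ccccc3)nc(NCOCc3ccc(/C=C/C(=O)Nc4ccccc4N)cc3)nc21`, gives 59.3%.

In a functional assay on HepG2 cells (Homo sapiens) for antiproliferative activity, read by CCK-8 assay, with a stated time of 72 h, tested at 8 uM (on this read-out lower numbers stand for a weaker effect and higher numbers for a stronger effect at the one concentration tested), compound 1 stands highest of the three numbers. Its nearest neighbour is compound 3, lower by a gap beyond the usual scatter, and the furthest is compound 2, lower by a gap also beyond the scatter. For the measured compounds named here, no pair of these measured compounds differs in a single place, so no isolated step is known.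

Compound 4, `Nc1ccccc1NC(=O)c1ccc(Cn2cnc3c(Nc4ccccc4)nc(Cl)nc32)cc1`, keeps the benzamide arm of compound 1 and changes the core: anilino in place of 4-methylpiperazin-1-yl on an aromatic carbon. Going by the values given here, compound 3 also carries an anilino group, though with a different arm and at another carbon of its core, and it gives 59.3%; this sets no direct precedent for the exchange. The expected step is a number 10 percentage points lower from compound 1 to compound 4 (within the scatter), a modest fall that may not clear the scatter. Compound 4 is estimated at 65%, with a range from 45% to 85%.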

Compound 4, a percentage reported as inhibition, at one concentration (the size of the read-out at that concentration, not a potency): 74.8%
Compound 4: middle estimate off by 9.8 percentage points, on the low side, and the stated range covers the measured number.
By their numbers in this assay, from the lowest: compound 2; then compound 3; then compounds 4 and 1 (each within the scatter of the next).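

In this assay, replacing 4-methylpiperazin-1-yl with anilino on this aromatic carbon gives a number 0.2 percentage points lower from compound 1 to compound 4 (within the scatter). The earlier compounds shown here could not show this, as no pair among them differed in one place. With the benzamide arm and the chloro group held constant, this position accepts either a non-aromatic ring with 2 hetero atoms and 0 hydrogen-bond donors or an aromatic ring of carbon only with 1 hydrogen-bond donor, with no separation between the two at the one concentration tested. Nothing at hand gives a reason for this equivalence.

On these data alone, whether a morpholin-4-yl group, a dimethylamino group or a benzylamino group would hold the read-out at this carbon remains open. A single concentration also leaves open whether compound 1 and compound 4 differ in potency.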